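Benzoyl capping of a hydroxylamine-bearing quinazoline analog

The source may report more compounds than this note shows. Statements on the series, on what has been measured and on what is new or still open speak of the compounds shown alone.

Measured so far in a functional assay on HepG2 cells (Homo sapiens) for antiproliferative activity, read by MTT assay, with a stated time of 48 h; on this read-out higher numbers stand for weaker inhibition and lower numbers for stronger inhibition:
- compound 1, `Cc1ccc(C(=O)Nc2ccc(Cl)cc2C(N)=O)cc1`: 21 ug/mL
- compound 2, `Cc1ccc(-c2nc3ccc(Cl)cc3c(=S)[nH]2)cc1`: 7.01 ug/mL
- compound 3, `Cc1ccc(-c2nc(NO)c3cc(Cl)ccc3n2)cc1`: 23.1 ug/mL

Compound 3 gives the highest number of the three, so the weakest inhibition. Its number and that of compound 1 lie within the scatter of each other, so no order can be read between them; compound 2 sits beyond the scatter, at a clearly lower number.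

Compound 4, `Cc1ccc(-c2nc(NOC(=O)c3ccccc3)c3cc(Cl)ccc3n2)cc1`, is not yet measured. It differs from compound 3 in one place: benzoyl in place of hydrogen on an oxygen. Going by the values given here, no pair of measured compounds shows this kind of change, so there is nothing to calibrate the step against. The expected step of a 1.5-fold lower number from compound 3 to compound 4 (0.19 log units; within the scatter) is small, likely within the usual scatter, with only a slight lean toward a lower number. Compound 4 is therefore estimated at 15 ug/mL, in the range 5 ug/mL to 45 ug/mL.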

Compound 4, half-maximal inhibitory concentration: 12.1 ug/mL
Compound 4: middle estimate off by 1.2-fold (0.09 log units), on the high side; the range from low to high includes it.
By their numbers in this assay, from the lowest: compounds 2, 4, 1 and 3 (each within the scatter of the next, the first and the last beyond it).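

In this assay, putting benzoyl in place of hydrogen on this oxygen gives a 1.9-fold lower number from compound 3 to compound 4 (0.28 log units; within the scatter). Going by these compounds alone, this is the first sign that this oxygen can carry a group as large as benzoyl, with its aromatic ring and carbonyl, without a change beyond the scatter, so the hydroxy hydrogen does not appear to be needed for this read-out. No supporting data are available to explain the size of this step. A single change at one position cannot show whether a smaller acetyl group or a simple methyl on the same oxygen would give a similar number.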